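The source may hold more compounds than are shown below. What is called first, only, known or untested is meant among the compounds shown, and "the series" means these compounds.

The measured compounds are:

compound 1, `COc1cc(/C=C/C(=O)CC(=O)/C=C/c2ccc(OC(C)=O)c(OC)c2)ccc1OC(C)=O`, which in an ADME assay on HEK293 cells (Homo sapiens) for cytotoxicity, read by resazurin assay, with a stated time of 16 h (a higher number here means that more compound is needed for the effect, a lower number that less compound is needed), gives 80000 nM;
compound 2, `COc1cc(/C=C/C(=O)CC(=O)/C=C/c2ccc(OC(C)=O)cc2)ccc1OC(C)=O`, which in this assay gives 49000 nM;
compound 3, `COc1cc(/C=C/C(=O)CC(=O)/C=C/c2ccc(OC(=O)c3ccccc3)c(OC)c2)ccc1O`, which in this assay gives 94000 nM.

All three values lie within the usual scatter of one another, so none of these compounds can be set apart from the others on this read-out. Compound 3 differs from compound 1 in more than one place, and the difference between the two cores is not broken down here.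

Compound 4, `COc1cc(/C=C/C(=O)CC(=O)/C=C/c2ccc(O)cc2)ccc1OC(=O)c1ccccc1`, has not yet been measured in this assay. It is related to compound 3 in the same way that compound 2 is related to compound 1. From compound 1 to compound 2 the change is hydrogen in place of methoxy on an aromatic carbon and the step it made was a 1.6-fold lower number from compound 1 to compound 2 (0.21 log units; within the scatter). From compound 3 to compound 4 the change is hydrogen in place of methoxy on an aromatic carbon. This is the same kind of change, but the surroundings differ: in the first case the carbon losing the methoxy sits ortho to an acetoxy group, in the second ortho to a hydroxy group.

Because a 1.6-fold lower number from compound 1 to compound 2 (0.21 log units; within the scatter) fell within the scatter, compound 4 is expected to sit close to compound 3, with an estimated step of a 1.6-fold lower number from compound 3 to compound 4 (0.19 log units; within the scatter). The estimate for compound 4 in this assay is 60000 nM, expected to lie between 30000 nM and 120000 nM.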

Compound 4, half-maximal effective concentration: 370000 nM
Compound 4: middle estimate off by 6.2-fold (0.79 log units), on the low side; the measured number lies above the stated range.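

In this assay the change from 4-hydroxy-3-methoxyphenyl to 4-hydroxyphenyl, with hydrogen entering in place of methoxy, gave a 3.9-fold higher number from compound 3 to compound 4 (0.60 log units; beyond the scatter), a modest step. Set beside the same replacement on the other core, this step shows that the change cannot be carried from one core to the other in this series as a fixed increment, since the two steps differ: the same change on two cores in this assay, a 1.6-fold lower number (0.21 log units; within the scatter) from compound 1 to compound 2 and a 3.9-fold higher number (0.60 log units; beyond the scatter) from compound 3 to compound 4, 6.4-fold (0.81 log units) apart, beyond the scatter of two such steps

Among these compounds, what this does not show is which of the differences between the two cores is responsible, and with only one pair on each core it offers no rule for predicting the change on any further core.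

The compounds shown leave open how the same place on the ring would respond to other replacements, such as an ethoxy group, a fluorine atom or an amine in place of the methoxy. They also leave open whether a compound with a free hydroxy group on both aromatic rings and no ester at all would give a step resembling either of these two, or a different one again.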